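Replacing a Chloro Group by Amino on Compound 2

This account rests on a few compounds, and the source may have more. Where it says the series, first, only, none or still open, it means among the compounds named here.

Of the compounds shown here, three have so far been tested in a functional assay on 786-0 cells (Homo sapiens) for cytotoxicity, read by sulforhodamine B assay, with a stated time of 48 h; on this read-out higher numbers stand for lower toxicity in this test and lower numbers for higher toxicity in this test. Compound 1 `ClCc1ccc(Cn2cnc3c(Cl)ncnc32)cc1` gives 21400 nM, compound 3 `ClCc1cccc(Cn2cnc3c(Cl)ncnc32)c1` gives 50100 nM, and compound 2 `ClCc1ccccc1Cn1cnc2c(Cl)nc(Cl)nc21` gives 6450 nM, the lowest of the three numbers and therefore the most toxic in this test, as its gaps to compound 1 and to compound 3 both lie beyond the scatter. Attention now turns to compound 4 `Nc1nc(Cl)c2ncn(Cc3ccccc3CCl)c2n1`, which differs from compound 2 by amino in place of chloro on an aromatic carbon. Among the compounds with values here, no measured pair in this set shows such an exchange, so its effect here is unknown. The expected step of a 1.4-fold higher number from compound 2 to compound 4 (0.14 log units; within the scatter) is a modest one, not clearly beyond the scatter, in either direction. Compound 4 is accordingly estimated to give about 9000 nM in this assay, within a range from 3000 nM to 30000 nM.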

Compound 4, concentration lethal to 50% of the cells: > 100000 nM
Compound 4 gave a limit, no number; the forecaster's own chance of this, stated with the estimate: 5%; middle value at least 11-fold (1.04 log units) away from the limit.
By their numbers in this assay, from the lowest: compound 2; then compound 1; then compound 3. At a limit, above all of these: compound 4.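

At this carbon between two ring nitrogen atoms, the exchange of chloro for amino gives an at least 15-fold higher number from compound 2 to compound 4 (1.19 log units; beyond the scatter) in this assay, the first measured sign that this one place strongly governs toxicity in this test. Compound 4 stands at a limit of the assay, > 100000 nM, and not at a number. The full size of the step therefore stays unfixed: the limit of > 100000 nM in this assay, at which 1 of the 4 values shown sits.

Going by these compounds, whether a methylamino, methoxy or hydroxyl group at this place would act like amino remains open. So does whether the same exchange would have so large a step on another compound.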